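Swapping Benzyloxy for Methyl on the Shared Core

This account rests on a few compounds, and the source may have more. Where it says the series, first, only, none or still open, it means among the compounds named here.

In a functional assay on MCF7 cells (Homo sapiens) for antiproliferative activity, read by MTT assay, with a stated time of 48 h (a higher number here means a weaker inhibitor, a lower number a stronger inhibitor), compound 1 `N=C(N)N/N=C(/C=C/c1ccccc1)c1ccccc1` gives 17000 nM, while compound 2 `N=C(N)N/N=C(/C=C/c1ccc(OCc2ccccc2)cc1)c1ccccc1` gives 1200 nM. Going by the values given here, compound 2 therefore holds the lower of the two numbers measured so far, which makes it the stronger inhibitor of the pair.

Compound 3 `Cc1ccc(/C=C/C(=N/NC(=N)N)c2ccccc2)cc1` has not yet been measured. It differs from compound 2 by having methyl in place of benzyloxy on an aromatic carbon.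

Among the compounds with values here, only one measured step bears on this change: a 14-fold lower number from compound 1 to compound 2 (1.15 log units; beyond the scatter). That large step came with benzyloxy in place of hydrogen on an aromatic carbon. Compound 3 gives up that benzyloxy, so a move back toward compound 1 seems likely, meaning a higher number in this assay. Within the data shown here, no methyl compound has been measured, so how much of the large step would be lost remains uncertain, and the expectation is correspondingly loose.

The expected change is a 5.8-fold higher number from compound 2 to compound 3 (0.77 log units; beyond the scatter). For compound 3, the estimated value is 7000 nM, with an expected range of 2500 nM to 20000 nM.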

Compound 3, half-maximal inhibitory concentration: 16000 nM
Compound 3: middle estimate off by 2.3-fold (0.36 log units), on the low side; measured number inside the range.
By their numbers in this assay, from the lowest: compound 2; then compounds 3 and 1 (each within the scatter of the next).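

Putting methyl in place of benzyloxy on this aromatic carbon, para to a large group, gives a 13-fold higher number from compound 2 to compound 3 (1.12 log units; beyond the scatter) in this assay. Compound 3 does not keep the large gain that came with benzyloxy. Methyl in place of hydrogen at the same position gives a 1.1-fold lower number from compound 1 to compound 3 (0.03 log units; within the scatter), which leaves compound 1 and compound 3 within the scatter of each other, so among these three compounds only benzyloxy goes with the lower number, and a small carbon group at this position does not. No measurement available here accounts for the gap between benzyloxy and methyl.

The compounds shown leave open which part of benzyloxy goes with the gain: its oxygen, its aromatic ring or the carbon linking the two. Methoxy, which keeps the oxygen without the ring, and benzyl, which keeps the ring without the oxygen, would help separate these parts, while an amine or a carboxylic acid at this position remains an open case.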